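A few compounds are considered here, and "the series" means these few. Any claim that something is new, unique, unknown or untested is made for them only; others in the source may bear on it.

Compound 1 `COc1cc(-c2cc(C(=O)O)c3ccccc3n2)ccc1OCC(=O)Nc1cccc(C)c1`, compound 2 `COc1cc(-c2cc(C(=O)O)c3ccccc3n2)ccc1OCC(=O)Nc1ccc(F)cc1` and compound 3 `COc1cc(-c2cc(C(=O)O)c3ccccc3n2)ccc1OCC(=O)Nc1ccc(Cl)cc1` share one core and differ only in the group on the amide-type nitrogen. In an ADME assay on HaCaT cells (Homo sapiens) for inhibition (on this read-out lower numbers stand for stronger inhibition and higher numbers for weaker inhibition), compound 1 gives 225000 nM. In this assay compound 2 gives 286000 nM. For compound 3 the read-out in this assay is only a limit, > 300000 nM. For the measured compounds named here, none of the measured steps leaves the scatter: a 1.3-fold higher number from compound 1 to compound 2 (0.10 log units; within the scatter), an at least 1.3-fold higher number from compound 1 to compound 3 (0.12 log units; that floor lies within the scatter) and an at least 1.0-fold higher number from compound 2 to compound 3 (0.02 log units; that floor lies within the scatter). Compound 3 therefore stands at the limit of > 300000 nM in this assay, at which 1 of the 3 values shown sits, without a number of its own.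

Compound 4 `COc1cc(-c2cc(C(=O)O)c3ccccc3n2)ccc1OCC(=O)Nc1cccc(C(F)(F)F)c1` has not yet been measured in this assay. The change from compound 3 is 3-(trifluoromethyl)phenyl in place of 4-chlorophenyl on an amide-type nitrogen. Every step measured so far among compound 1, compound 2 and compound 3 lies within the scatter, so no step beyond the scatter is expected here either: the estimated step is a number no higher from compound 3 to compound 4 (the limit leaves the size open). Compound 4 is expected to give 300000 nM in this assay, with a likely range from 150000 nM to 700000 nM, and it may well again return only a limit.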

Compound 4, half-maximal inhibitory concentration: 160000 nM
The estimate for compound 4 lay 1.9-fold (0.27 log units) above the measured number, and the stated range covers the measured number.
By their numbers in this assay, from the lowest: compounds 4, 1 and 2 (each within the scatter of the next). At a limit, above all of these: compound 3.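

In this assay the steps of a 1.8-fold lower number from compound 2 to compound 4 (0.25 log units; within the scatter) and a 1.4-fold lower number from compound 1 to compound 4 (0.15 log units; within the scatter) both stay within the scatter, so 3-(trifluoromethyl)phenyl on the amide-type nitrogen does not separate from the groups of compound 1 and compound 2. Wherever a step can be read, the groups shown at this place now stay within the scatter of one another, and this includes trifluoromethyl in place of methyl on an aromatic carbon. The remaining step is an at least 1.8-fold lower number from compound 3 to compound 4 (0.27 log units; that floor lies within the scatter) and its true size cannot be read, since one end of it is only a limit: the limit of > 300000 nM in this assay, at which 1 of the 4 values shown sits.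

Every group shown on this nitrogen is a substituted phenyl, so it remains open whether a longer chain carrying an amine would move the number beyond the scatter. On these data alone, it also remains open what an ester in place of the carboxylic acid would do.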